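The source may report more compounds than this note shows. Statements on the series, on what has been measured and on what is new or still open speak of the compounds shown alone.

In a functional assay on PC-3 cells (Homo sapiens) for inhibition, read by colorimetric assay and MTT assay, with a stated time of 72 h (on this read-out higher numbers stand for weaker inhibition and lower numbers for stronger inhibition), compound 1 `C=CCCCCCOc1ncc(-c2ccccc2OCCCCC=C)n1C` gives 70000 nM and compound 3 `C=CCCCCOc1ncc(-c2cc(F)c(F)cc2OC)n1C` gives 40000 nM and these two values lie within the scatter of each other. Compound 2 `COc1ccccc1-c1cnc(OC)n1C` reads > 100000 nM as a limit of the assay and not a number. Compound 4 `C=CCCCCOc1ccccc1-c1cnc(NC(=O)CCCC=C)n1C` remains to be measured. Relative to compound 1, it carries ((pent-4-en-1-yl)carbonyl)amino in place of (hept-6-en-1-yl)oxy on an aromatic carbon between two ring nitrogen atoms: ((pent-4-en-1-yl)carbonyl)amino in place of (hept-6-en-1-yl)oxy on an aromatic carbon is the whole difference. Among the compounds with values here, no measured pair isolates this change. The expected step is a 1.4-fold lower number from compound 1 to compound 4 (0.15 log units; within the scatter) and it is expected to stay within the scatter, with no firm direction. With compound 1 at 70000 nM as the anchor, compound 4 is estimated at 50000 nM with an expected range from 20000 nM to 100000 nM in this read-out.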

Compound 4, half-maximal inhibitory concentration: 11000 nM
Compound 4: middle estimate off by 4.5-fold (0.66 log units), on the high side; the whole stated range lies above it.
By their numbers in this assay, from the lowest: compound 4; then compounds 3 and 1 (each within the scatter of the next). At a limit, above all of these: compound 2.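

At the aromatic carbon between two ring nitrogen atoms, ((pent-4-en-1-yl)carbonyl)amino in place of (hept-6-en-1-yl)oxy gives a 6.4-fold lower number from compound 1 to compound 4 (0.80 log units; beyond the scatter) in this assay, so this position can move the read-out beyond the scatter. Within the data shown here, the entering group holds a hydrogen-bond donor and the leaving group none, whereas the earlier compounds carry only oxygen-linked groups here. No measurement shown accounts for the step.

From the compounds shown here alone, whether the amide hydrogen or the carbonyl carries the step remains open. So does the outcome with a plain amine, a carboxylic acid or a longer chain on the amide at this position.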